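The source may report more compounds than this note shows. Statements on the series, on what has been measured and on what is new or still open speak of the compounds shown alone.

Measured in a functional assay on CCRF-CEM cells (Homo sapiens) for cytotoxicity; on this read-out lower numbers stand for higher toxicity in this test and higher numbers for lower toxicity in this test:
- Compound 1 `O=C1c2ccccc2NS(=O)(=O)N1COCCO`: > 200 ug/mL
- Compound 2 `O=C1c2ccccc2NS(=O)(=O)N1Cc1ccccc1`: > 200 ug/mL

Compound 2 stands at > 200 ug/mL, a limit and not a number. Compound 1 gives > 200 ug/mL, likewise a limit. Thus (the limit of > 200 ug/mL in this assay, at which 2 of the 2 values shown sit), and no number is available in this series so far.

Compound 3 `C#CCOCN1c2ccccc2C(=O)N(Cc2ccccc2)S1(=O)=O` arises from compound 2 by one change: (propargyloxy)methyl in place of hydrogen on a sulfonamide nitrogen in a ring. Within the data shown here, the group replaces the hydrogen on a sulfonamide nitrogen in a ring, and no measured compound is substituted there. Among the measured compounds shown here, the only measured step, a step that the two limits leave unreadable from compound 1 to compound 2, lies elsewhere and gives no size to carry over.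

A readable result in this assay could therefore fall only toward lower numbers, and a further limit remains about as likely. The expected step is an at least 1.3-fold lower number from compound 2 to compound 3 (0.12 log units; that floor lies within the scatter), a rough estimate. For compound 3 the estimated value is 150 ug/mL, with an expected range of 40 ug/mL to 300 ug/mL.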

Compound 3, half-maximal cytotoxic concentration: 23 ug/mL
The estimate for compound 3 lay 6.5-fold (0.81 log units) above the measured number; measured number outside the range, below it.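

In this assay, among these compounds, (propargyloxy)methyl in place of hydrogen on the sulfonamide nitrogen in a ring gives an at least 8.6-fold lower number from compound 2 to compound 3 (0.93 log units; beyond the scatter), so substitution at this position is the first change to yield a readable number. The earlier step, from compound 1 to compound 2, cannot be read, and so the group carried by the ring atom that bears the benzyl group has shown no effect so far. The step is only a floor and not a full size because compound 2 sits at a limit: the limit of > 200 ug/mL in this assay, at which 2 of the 3 values shown sit.

The compounds shown leave open whether the triple bond matters, which a saturated propoxymethyl group or a plain methyl on the same nitrogen would test. Also open, from the compounds shown here alone, is whether the step persists when (propargyloxy)methyl is paired with the 2-hydroxyethoxy side chain of compound 1 instead of the benzyl group.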